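Series notes: benzyl variation at the imidazole-bound chain carbon

The source may hold more compounds than are shown below. What is called first, only, known or untested is meant among the compounds shown, and "the series" means these compounds.

Measured compounds:
Compound 1 `COC(=O)[C@H](CCSC)NC(=O)c1ccc(NCc2cncn2Cc2ccc(Cl)cc2)cc1-c1ccccc1` — in a functional assay on NIH3T3 cells (Mus musculus) (a lower number here means that less compound is needed, a higher number that more compound is needed for the effect), compound 1 gives > 10 uM, a limit of the assay.
Compound 2 `COC(=O)[C@H](CCSC)NC(=O)c1ccc(NCc2cncn2Cc2ccccc2C)cc1-c1ccccc1` — in this assay compound 2 gives > 10 uM, also a limit of the assay.

Compound 2 therefore stands at the upper limit in this assay, with no number of its own. Going by the values given here, the only measured step, a step that the two limits leave unreadable from compound 1 to compound 2, is unreadable, since the limit of > 10 uM in this assay, at which 2 of the 2 values shown sit, covers both values.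

Compound 3 `COC(=O)[C@H](CCSC)NC(=O)c1ccc(NCc2cncn2Cc2cccc([N+](=O)[O-])c2)cc1-c1ccccc1` is the next member. The change from compound 2 is 3-nitrophenyl in place of 2-methylphenyl on a saturated chain carbon bound to an aromatic nitrogen; cut one bond further out it reads 2-methylbenzyl to 3-nitrobenzyl. Among the compounds with values here, no measured step bears on this change beyond the unreadable one, so the expectation rests on compound 2 sitting at the limit in this assay.

Compound 3 is expected to remain near or at that limit, with an estimated step that the limit leaves unreadable from compound 2 to compound 3 from compound 2 to compound 3. The estimate for compound 3 in this assay is 15 uM, within 4 uM to 60 uM.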

Compound 3, concentration for half-maximal effect: > 10 uM
Compound 3 gave a limit, no number; the forecaster's own chance of this, stated with the estimate: 75%; the middle value lies beyond the limit too.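

No step can be read among compound 1, compound 2 and compound 3 in this assay, because all three values are limits and not numbers: the limit of > 10 uM in this assay, at which 3 of the 3 values shown sit.

The compounds shown leave open whether the 4-chlorophenyl, 2-methylphenyl and 3-nitrophenyl variants differ at all in this assay.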